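Fluoro to methyl: what to expect for compound 4

The compounds below may be only part of what the source reports. "The series", "measured", "known", "first", "only" and "open" are said of these compounds alone.

Measured so far in an assay for inhibition of Indoleamine 2,3-dioxygenase 1 (Homo sapiens), with a stated time of 1 h, tested at 10 uM; on this read-out lower numbers stand for less inhibition and higher numbers for more inhibition at the one concentration tested (going by the name of the read-out):
compound 1 `Nc1cccc(CNc2cc(Br)cc3[nH]ncc23)c1` gives 31%
compound 2 `Oc1ccc(CNc2cc(Br)cc3[nH]ncc23)c(O)c1` gives 40%
compound 3 `Oc1ccc(CNc2cc(Br)cc3[nH]ncc23)c(F)c1` gives 69%

Compound 3 stands highest of the three numbers, beyond the scatter above both others. Among the compounds with values here, the only single-change step measured so far, a number 29 percentage points higher from compound 2 to compound 3 (beyond the scatter), came from fluoro in place of hydroxy on an aromatic carbon, a modest rise. Compound 4 `Cc1cc(O)ccc1CNc1cc(Br)cc2[nH]ncc12` changes that same carbon again: methyl in place of fluoro on an aromatic carbon. Within the data shown here, no measured step puts methyl there, so the direction is open; the one step available only shows that the group on that carbon matters. The step of a number 17 percentage points lower from compound 3 to compound 4 (beyond the scatter) is therefore expected to be small and uncertain. Compound 4 is estimated at 52%, within 25% to 78%.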

Compound 4, a percentage reported as inhibition, at one concentration (the size of the read-out at that concentration, not a potency): 60%
Compound 4: the middle estimate sits 8 percentage points below what was measured; measured number inside the range.
By their numbers in this assay, from the lowest: compounds 1 and 2 (each within the scatter of the next); then compounds 4 and 3 (each within the scatter of the next).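

Methyl in place of fluoro on this aromatic carbon gives a number 9 percentage points lower from compound 3 to compound 4 (within the scatter), so the two groups cannot be told apart here. Methyl in place of hydroxy gives a number 20 percentage points higher from compound 2 to compound 4 (beyond the scatter), so a second group now stands clear of hydroxy at this place, as fluoro already did. Nothing in the data explains why these groups compare as they do.

From the compounds shown here alone, whether chloro, methoxy or an amine on this carbon would read like fluoro and methyl or like hydroxy stays open. So does the outcome for a longer chain, such as ethyl.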